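This account rests on a few compounds, and the source may have more. Where it says the series, first, only, none or still open, it means among the compounds named here.

In a functional assay on DU-145 cells (Homo sapiens) for inhibition, read by trypan blue exclusion, with a stated time of 96 h (a higher number here means a weaker inhibitor of growth, a lower number a stronger inhibitor of growth), compound 1 (`O=C(/C(=C\c1c[nH]c2ccc(Br)cc12)SCc1ccc(Cl)cc1Cl)c1ccc(Cl)cc1`) gives 10000 nM, compound 2 (`O=C(/C(=C\c1c[nH]c2ccccc12)SCc1ccc(F)cc1)c1ccc(Cl)cc1`) gives 1000 nM and compound 3 (`O=C(/C(=C\c1ccc(Br)cc1)SCc1ccc(F)cc1)c1ccc(Cl)cc1`) gives 9000 nM. Compound 3 and compound 1 lie within the scatter of each other, and compound 2 has the lowest number of the three. Compound 4 (`O=C(/C(=C\c1c[nH]c2ccc(Br)cc12)SCc1ccc(F)cc1)c1ccc(Cl)cc1`) differs from compound 3 by one change: 5-bromo-1H-indol-3-yl in place of 4-bromophenyl on a double-bonded chain carbon bound to a double-bonded chain carbon.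

Within the data shown here, only one measured step bears on this place, a 9.0-fold higher number from compound 2 to compound 3 (0.95 log units; beyond the scatter), which puts 4-bromophenyl in place of 1H-indol-3-yl. The change to compound 4 runs the opposite way, so a lower number is expected in this assay. However, the entering group is 5-bromo-1H-indol-3-yl, not 1H-indol-3-yl, and the data hold no direct comparison of the two with all else equal. Compound 1, which also carries 5-bromo-1H-indol-3-yl, gives 10000 nM, so only part of the measured step is expected to return.

The expected change is a 3.0-fold lower number from compound 3 to compound 4 (0.48 log units; beyond the scatter). For compound 4 the estimated value is 3000 nM, with an expected range of 800 nM to 10000 nM.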

Compound 4, concentration for 50% growth inhibition: 50000 nM
Compound 4: middle estimate off by 17-fold (1.22 log units), on the low side, and the stated range ends below it.
By their numbers in this assay, from the lowest: compound 2; then compounds 3 and 1 (each within the scatter of the next); then compound 4.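

In this assay the gain seen for 1H-indol-3-yl over 4-bromophenyl does not carry over to 5-bromo-1H-indol-3-yl, which reverses the direction of the change (a 5.6-fold higher number from compound 3 to compound 4 (0.74 log units; beyond the scatter)). The bromo in place of hydrogen on an aromatic carbon gives the largest step in the series (a 50-fold higher number from compound 2 to compound 4 (1.70 log units; beyond the scatter)), so the loss traces to this one substituent rather than to the indole as such. With the bromo in place, 4-fluorophenyl in place of 2,4-dichlorophenyl on a saturated chain carbon bound to a sulfur also gives a higher number (a 5.0-fold higher number from compound 1 to compound 4 (0.70 log units; beyond the scatter)), so this second place matters too.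

As far as these compounds go, whether methoxy or an amine in place of the bromo would keep the number close to that of compound 2 remains open. Nothing at hand gives a reason for any of these steps.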